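The source may report more compounds than this note shows. Statements on the series, on what has been measured and on what is new or still open speak of the compounds shown alone.

In a functional assay on HL-60 cells (Homo sapiens) for inhibition, read by CCK-8 assay, with a stated time of 48 h (on this read-out lower numbers stand for stronger inhibition and higher numbers for weaker inhibition), compound 3 `COc1cccc(NC(=S)NCCNS(=O)(=O)c2ccc(-c3ccccc3Oc3ccc([N+](=O)[O-])cc3)s2)c1` gives > 50000 nM, which is a limit of the assay and not a number. Compound 2 `COc1ccc(NC(=O)NCCNS(=O)(=O)c2ccc(-c3ccccc3OCc3ccccc3)s2)cc1` gives > 50000 nM, also a limit. Compound 1 `COc1ccc(Oc2ccc(C(C)C)cc2-c2ccsc2S(=O)(=O)NCCNC(=S)Nc2ccc([N+](=O)[O-])cc2)cc1OC` is the only one of these with a true number, at 11200 nM. The overall picture is therefore (the limit of > 50000 nM in this assay, at which 2 of the 3 values shown sit), so the data offer little to compare.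

The next compound, compound 4 `COc1ccc(NC(=O)NCCNS(=O)(=O)c2ccc(-c3ccccc3Oc3ccc([N+](=O)[O-])cc3)s2)cc1`, differs from compound 3 in one place, on an amine nitrogen whose other neighbour is a saturated chain carbon: a group of 11 heavy atoms (8 carbon, 1 nitrogen, 2 oxygen; one six-membered aromatic ring of carbon only) in place of a group of 11 heavy atoms (8 carbon, 1 nitrogen, 1 oxygen, 1 sulfur; one six-membered aromatic ring of carbon only), on an amine nitrogen. The entering group, (4-methoxyphenyl)carbamoyl, is also present in compound 2, which reaches only the limit of > 50000 nM.

Going by the values given here, no measured step shows what this swap does, so no change beyond the usual scatter is expected in this assay, and the result may again be only a limit. The expected step, a number no higher from compound 3 to compound 4 (the limit leaves the size open), is therefore small. Compound 4 is estimated at 50000 nM, with an expected range of 15000 nM to 150000 nM.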

Compound 4, half-maximal inhibitory concentration: > 50000 nM
Compound 4 ended at the assay's limit; the forecaster's own chance of this, stated with the estimate: 65%; the middle value lies on the limit itself.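

Compound 2, compound 3 and compound 4 all end at a limit of the assay and not a number, so the steps from compound 3 and from compound 2 to compound 4 cannot be read. Whether either swap changes inhibition at all stays open, with most values at one limit: the limit of > 50000 nM in this assay, at which 3 of the 4 values shown sit.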